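A few compounds are considered here, and "the series" means these few. Any claim that something is new, unique, unknown or untested is made for them only; others in the source may bear on it.

In a functional assay on HCT-116 cells (Homo sapiens) for cytotoxicity, read by hypoxanthine incorporation, with a stated time of 72 h, tested at 10 uM (on this read-out lower numbers stand for less inhibition of growth and higher numbers for more inhibition of growth at the one concentration tested), compound 1 (`CC(C)C[C@@H]1NC(=O)[C@H](CCCN)NC(=O)[C@H](C(C)C)NC(=O)[C@H](CC(C)C)NC(=O)[C@@H](Cc2ccc(O)cc2)NC1=O`) stands at 0% in these notes, compound 2 (`CC(C)C[C@@H]1NC(=O)[C@H](Cc2ccccc2)NC(=O)[C@@H](Cc2ccccc2)NC(=O)[C@@H](CCCCNC(=O)OCc2ccc(Cl)cc2)NC(=O)[C@H](C(C)C)N(C)C1=O`) at 69% and compound 3 (`CC(C)C[C@@H]1NC(=O)[C@@H]([C@H](OCc2ccccc2)c2ccccc2)NC(=O)[C@@H](Cc2ccccc2)NC(=O)[C@@H](CC(C)C)NC(=O)[C@H](C(C)C)N(C)C1=O`) at 94% as the highest of the three. Compound 3 lies beyond the scatter from both compound 2 and compound 1. The next entry is compound 4 (`CC(C)C[C@@H]1NC(=O)[C@H]([C@@H](OCc2ccccc2)c2ccccc2)NC(=O)[C@@H](Cc2ccccc2)NC(=O)[C@@H](CC(C)C)NC(=O)[C@H](C(C)C)N(C)C1=O`), related to compound 3 by the two compounds have the same atoms and bonds and differ only in configuration as drawn: 2 of 6 stereo elements differ; a stereocentre at a saturated ring carbon is drawn R in compound 3 and S in compound 4; a stereocentre at a saturated chain carbon is drawn R in compound 3 and S in compound 4 with nothing leaving and nothing entering. A stereocentre at a saturated ring carbon is drawn R in compound 3 and S in compound 4, and a stereocentre at a saturated chain carbon is also drawn R in compound 3 and S in compound 4.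

Within the data shown here, no measured pair differs in configuration alone, so the data give no direct size for such a change. Compound 3 at 94% sits high enough to leave little room upward, so any clear move is more likely to be down. The wide spread among the measured compounds also leaves a large loss open. A downward move beyond the scatter is expected in this assay, with a number 22 percentage points lower from compound 3 to compound 4 (beyond the scatter) as the estimated step and wide uncertainty around it. For compound 4 the estimated value is 72% with an expected range from 35% to 97% at the one concentration tested.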

Compound 4, percent growth inhibition at one concentration: 64%
Compound 4: the middle estimate sits 8 percentage points above what was measured; the measured number falls inside the stated range.
By their numbers in this assay, from the lowest: compound 1; then compounds 4 and 2 (each within the scatter of the next); then compound 3.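

In this assay the series now has its first measured size for a change of configuration alone, with a number 30 percentage points lower from compound 3 to compound 4 (beyond the scatter). With nothing leaving and nothing entering, the loss of growth inhibition can be placed on the configuration and not on any exchange of groups: the fact that compounds 3 and 4 differ only in the configuration as drawn. Two stereocentres, one at a saturated ring carbon and one at a saturated chain carbon, go from R to S together, and this inverted arrangement is not inactive, since compound 4 still gives 64%.

Which of the two stereocentres carries the step stays open, as does the result of inverting only one of them while the other stays as drawn in compound 3. Also open, on these data alone, is how a carboxylic acid or a longer chain in place of the benzyl ether on this side chain would read in this assay, and whether the two configurations would still stand apart with such a group.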